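The source may hold more compounds than are shown below. What is called first, only, known or untested is meant among the compounds shown, and "the series" means these compounds.

Measured so far in a functional assay with Alpha-1B adrenergic receptor (Homo sapiens) as the target, read by calcium flux; a higher number here means a larger maximal response, a lower number a smaller maximal response:

compound 1 `CC(C)n1ncnc1-c1ccccc1NCC1=NCCN1` gives 0%
compound 2 `Cn1cccc1-c1ccccc1NCC1=NCCN1` gives 0%
compound 3 `Cn1cc(-c2ccccc2NCC2=NCCN2)cn1` gives 0%

Compound 3 stands level with compound 1 and compound 2 in this assay; none of the three produces a response. Within the data shown here, the one measured step between these compounds, no change at the digits printed from compound 2 to compound 3 (within the scatter), swapped one five-membered aromatic ring for another without moving the read-out.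

Compound 4 `Cn1ncnc1-c1ccccc1NCC1=NCCN1` differs from compound 3 in the same way: 1-methyl-1H-1,2,4-triazol-5-yl in place of 1-methyl-1H-pyrazol-4-yl on an aromatic carbon

Since the comparable exchange of one small aromatic ring for another left the read-out unchanged, the expected step of no change at the digits printed from compound 3 to compound 4 (within the scatter) is none beyond the scatter. Compound 4 is therefore estimated to give 0%, within a range of 0% to 10%, in this assay.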

Compound 4, largest response reached (reported as maximal response), in percent of the reference or control that the assay uses: 93%
Compound 4: the middle estimate sits 93 percentage points below what was measured; the measured number lies above the stated range.
By their numbers in this assay, from the lowest: compounds 1, 2 and 3 (each within the scatter of the next); then compound 4.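

In this assay, the five-membered ring on this aromatic carbon turns out to matter: 1-methyl-1H-1,2,4-triazol-5-yl gives a number 93 percentage points higher from compound 3 to compound 4 (beyond the scatter) and also a number 93 percentage points higher from compound 2 to compound 4 (beyond the scatter), although the earlier ring exchange changed nothing. The group on the aromatic nitrogen counts as well, since methyl in place of isopropyl gives a number 93 percentage points higher from compound 1 to compound 4 (beyond the scatter). Nothing available here explains why these changes bring a response. Still open, on these data alone, is whether the response survives with an ethyl group on that nitrogen, or with an amine added to the 1-methyl-1H-1,2,4-triazol-5-yl ring.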